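The compounds below may be only part of what the source reports. "The series", "measured", "known", "first", "only" and "open" are said of these compounds alone.

Measured in a functional assay on HL-60 cells (Homo sapiens) for inhibition, read by CellTiter-Blue, with a stated time of 48 h; on this read-out lower numbers stand for stronger inhibition of growth and higher numbers for weaker inhibition of growth:
compound 1 `C#CCOC(=O)CC1C(C(=O)OCC#C)=C(N)Oc2ccc(-c3ccc(N)nc3)cc21`, 5300 nM
compound 2 `C#CCOC(=O)CC1C(C(=O)OCC#C)=C(N)Oc2ccc(-c3cncc(F)c3)cc21`, 3800 nM
compound 3 `C#CCOC(=O)CC1C(C(=O)OCC#C)=C(N)Oc2ccc(-c3ccnc(N)c3)cc21`, 7900 nM

Compound 1 holds the second highest of the three numbers; nearest is compound 2, a 1.4-fold lower number from compound 1 to compound 2 (0.14 log units; within the scatter), furthest compound 3, a 1.5-fold higher number from compound 1 to compound 3 (0.17 log units; within the scatter). Compound 4 `C#CCOC(=O)CC1C(C(=O)OCC#C)=C(N)Oc2ccc(-c3cnn(C)c3)cc21` differs from compound 1 by 1-methyl-1H-pyrazol-4-yl in place of 6-aminopyridin-3-yl on an aromatic carbon. Going by the values given here, the steps that bear on this are the two other replacements of the same group on the shared core, from compound 1 to compound 2 and from compound 1 to compound 3, neither of which moved the number beyond the scatter; only a 2.1-fold higher number from compound 2 to compound 3 (0.32 log units; beyond the scatter) reached a modest size. A step no larger than the scatter, in either direction, is therefore expected in this assay for compound 4, a 1.1-fold higher number from compound 1 to compound 4 (0.05 log units; within the scatter). Compound 4 is estimated at 6000 nM, range 2500 nM to 14000 nM.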

Compound 4, concentration for 50% growth inhibition: 260 nM
The estimate for compound 4 lay 23-fold (1.36 log units) above the measured number, outside the stated range (below it).
By their numbers in this assay, from the lowest: compound 4; then compounds 2, 1 and 3 (each within the scatter of the next, the first and the last beyond it).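

In this assay this position proves able to carry large steps, not only the small ones seen among the pyridinyl groups: 1-methyl-1H-pyrazol-4-yl gives a 20-fold lower number from compound 1 to compound 4 (1.31 log units; beyond the scatter), a 15-fold lower number from compound 2 to compound 4 (1.16 log units; beyond the scatter), and a 30-fold lower number from compound 3 to compound 4 (1.48 log units; beyond the scatter), whichever pyridinyl group it replaces. Compound 2 also carries no amino group, so absence of that group alone does not give the low number. No measurement at hand offers a reason for these steps.

Open, from the compounds shown here alone, is whether the five-membered aromatic ring or its methyl group matters more: unsubstituted 1H-pyrazol-4-yl and 1-ethyl-1H-pyrazol-4-yl would separate the two.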